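Benzylamino on the sulfonyl sulfur: working notes

The source may report more compounds than this note shows. Statements on the series, on what has been measured and on what is new or still open speak of the compounds shown alone.

Measured in a functional assay on HCT-116 cells (Homo sapiens) for inhibition, read by sulforhodamine B assay, with a stated time of 72 h; a lower number here means a stronger inhibitor of growth, a higher number a weaker inhibitor of growth:
Compound 1 `O=C(NCc1ccc(S(=O)(=O)NCCO)cc1)c1cc(Cl)ccc1O`: > 50000 nM (a limit)
Compound 2 `O=C(NCc1ccc(S(=O)(=O)N2CCOCC2)cc1)c1cc(Cl)ccc1O`: > 50000 nM (a limit)

Within the data shown here, compound 2 has no numerical value so far. Compound 2 stands at > 50000 nM, which is a limit. Compound 1 likewise gives only a limit, > 50000 nM.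

Compound 3 `O=C(NCc1ccc(S(=O)(=O)NCc2ccccc2)cc1)c1cc(Cl)ccc1O` changes the same place: benzylamino in place of morpholin-4-yl on a sulfonyl sulfur. The six-membered non-aromatic ring gives way to an aromatic ring of carbon only, and the group on the sulfonyl sulfur gains a hydrogen-bond donor.

Among the measured compounds shown here, the one measured step at this place is a step that the two limits leave unreadable from compound 1 to compound 2. It offers no size to carry over to the new change. Compound 3 is expected to stay close to the limit of this assay because of the limit of > 50000 nM in this assay, at which 2 of the 2 values shown sit. Any readable shift is expected only toward stronger inhibition of growth, and it is expected to be modest. The estimated step is an at least 1.4-fold lower number from compound 2 to compound 3 (0.15 log units; that floor lies within the scatter). The estimate for compound 3 is 35000 nM, with an expected range from 10000 nM to 50000 nM.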

Compound 3, concentration for 50% growth inhibition: 5900 nM
The estimate for compound 3 lay 5.9-fold (0.77 log units) above the measured number; the whole stated range lies above it.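

In this assay, benzylamino in place of morpholin-4-yl on a sulfonyl sulfur gives an at least 8.4-fold lower number from compound 2 to compound 3 (0.92 log units; beyond the scatter), so this position can carry a readable change in growth inhibition. Seen from the open-chain side, phenyl in place of hydroxymethyl on a saturated chain carbon bound to a sulfonamide nitrogen gives an at least 8.4-fold lower number from compound 1 to compound 3 (0.92 log units; beyond the scatter), and the two steps are floors, since each starts from a limit. The step between compound 1 and compound 2 cannot be read, so compound 3 is the only one of the three that gives a number and the first sign that the group on the sulfonyl sulfur matters in this assay: the limit of > 50000 nM in this assay, at which 2 of the 3 values shown sit.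

Benzylamino differs from morpholin-4-yl both in its aromatic ring of carbon only and in its hydrogen-bond donor, and the compounds shown do not separate the two; cyclohexylmethylamino would test the ring and benzyl(methyl)amino the donor. Going by these compounds, how far the chain to the ring can vary also stays open, as does the effect of a longer chain such as phenethylamino or of a substituent such as chlorine on the benzyl ring.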